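Swapping a chloropropyl chain for a vinyl group

A few compounds are considered here, and "the series" means these few. Any claim that something is new, unique, unknown or untested is made for them only; others in the source may bear on it.

Compound 1 `O=C(CCCCl)Nc1ccc(I)cc1` and compound 3 `C=CC(=O)Nc1ccc(I)cc1` share one core; compound 2 `CCCCC(O)c1cccc(NC(=O)CCCCl)c1` and compound 4 `C=CC(=O)Nc1cccc(C(O)CCCC)c1` share another, and the difference between the two cores is not broken down here. In a functional assay on HT-29 cells (Homo sapiens) for antiproliferative activity, with a stated time of 48 h (a higher number here means a weaker inhibitor, a lower number a stronger inhibitor), compound 1 gives only a limit of the assay, > 100000 nM. Compound 2 likewise reaches only a limit of the assay, > 100000 nM. Compound 3, in this assay, gives 15000 nM. The change from compound 1 to compound 3 is vinyl in place of 3-chloropropyl on a carbonyl carbon, and it brought an at least 6.6-fold lower number from compound 1 to compound 3 (0.82 log units; beyond the scatter). The same change, (vinyl in place of 3-chloropropyl on a carbonyl carbon), separates compound 2 from compound 4, and compound 4 has not yet been measured in this assay. Because compound 2 sits at the limit of > 100000 nM in this assay, at which 2 of the 3 values shown sit, the earlier step can only be read as a lower bound, and the step from compound 2 to compound 4 is expected to be of a broadly similar size, an at least 5.0-fold lower number from compound 2 to compound 4 (0.69 log units; beyond the scatter). Compound 4 is therefore expected to give about 20000 nM, with a plausible range from 5000 nM to 100000 nM.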

Compound 4, half-maximal inhibitory concentration: > 100000 nM
Compound 4 was reported as a limit; the forecaster's own chance of this, stated with the estimate: 30%; middle value at least 5.0-fold (0.69 log units) away from the limit.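

In this assay, compound 2 and compound 4 each give only a limit of the assay, so the swap of 3-chloropropyl for vinyl yields no readable step between them: the limit of > 100000 nM in this assay, at which 3 of the 4 values shown sit.

The compounds shown leave open whether this swap changes activity at all on the core of compound 2, as it did on the core of compound 1.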